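The compounds below may be only part of what the source reports. "The series", "measured", "known", "first", "only" and "open" are said of these compounds alone.

Working notes on the sulfonamide series.

Compound 1 `Cc1ccc(S(=O)(=O)Nc2ccc(CN[C@@H]3CCN(C(=O)c4cccc(Cl)c4)C3)cc2)cc1` gives 75000 nM in a physicochemical assay for solubility, measured as kinetic solubility; a lower number here means a less soluble compound, a higher number a more soluble compound. Compound 2 `COc1ccc(S(=O)(=O)Nc2ccc(CN3CCN(C(=O)C4CC(O)(C(F)(F)F)C4)CC3)cc2)cc1` sits at a limit of this assay, reporting >= 374000 nM, so no number is known for it; of the three values shown, one sits at this limit (the limit of >= 374000 nM in this assay, at which 1 of the 3 values shown sits). Compound 3 `Cc1ccc(S(=O)(=O)Nc2ccc(CN(C)[C@H]3CCN(C(=O)c4cccc(Cl)c4)C3)cc2)cc1` gives 27000 nM, the lowest of the two numbers; the nearest is compound 1, whose value is higher by a margin beyond the scatter.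

The next step in the series goes from compound 3 to compound 4 `Cc1ccc(S(=O)(=O)Nc2ccc(CN[C@H]3CCN(C(=O)c4cccc(Cl)c4)C3)cc2)cc1`. The change is hydrogen in place of methyl on an amine nitrogen. Going by the values given here, no measured pair of compounds in this set differs in only this way, so the size of the step is not known from the data. Taking compound 3 at 27000 nM as the anchor, and noting that compound 1 carries a hydrogen at the same place and gives 75000 nM, a rise of modest size beyond the scatter is expected, a 2.6-fold higher number from compound 3 to compound 4 (0.41 log units; beyond the scatter). For compound 4 the expected value in this assay is 70000 nM, with a range from 30000 nM to 160000 nM.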

Compound 4, solubility: 72000 nM
The estimate for compound 4 lay 1.0-fold (0.01 log units) below the measured number; measured number inside the range.
By their numbers in this assay, from the lowest: compound 3; then compounds 4 and 1 (each within the scatter of the next). At a limit, above all of these: compound 2.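

Going by these compounds alone, for the first time, the amine nitrogen has a measured step in this assay: a 2.7-fold higher number from compound 3 to compound 4 (0.43 log units; beyond the scatter), with hydrogen in place of methyl. Changing the drawn configuration at the saturated ring carbon gives a step of a different kind: a 1.0-fold lower number from compound 1 to compound 4 (0.02 log units; within the scatter). Of these two single changes, only the one on the amine nitrogen gives a step beyond the scatter, and the reading for the stereocentre rests on one pair: the fact that compounds 1 and 4 differ only in the configuration as drawn

The step from methyl to hydrogen rests on a single pair with one drawn configuration, and the compounds shown leave open whether it carries over to the configuration drawn in compound 1. Also open, from the compounds shown here alone, is what an ethyl group, a longer chain or an acetyl group on this amine nitrogen would give in this assay.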